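Carbonate chain size against solubility in the series

This account rests on a few compounds, and the source may have more. Where it says the series, first, only, none or still open, it means among the compounds named here.

Measured compounds:
compound 1 `CC(C)COC(=O)OCC(CO)CCn1cnc2cnc(N)nc21`: 1500 ug/mL
compound 2 `COC(=O)OCC(CO)CCn1cnc2cnc(N)nc21`: 14100 ug/mL

In a physicochemical assay for solubility, read by spectrophotometry, at 20 degrees C (a higher number here means a more soluble compound, a lower number a less soluble compound), compound 1 gives 1500 ug/mL, the lowest of the two numbers in hand; its nearest neighbour is compound 2, which shows a 9.4-fold higher number from compound 1 to compound 2 (0.97 log units; beyond the scatter). That step changes the carbonate chain by hydrogen in place of isopropyl on a saturated chain carbon bound to an oxygen next to a carbonyl group.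

Compound 3 `CCOC(=O)OCC(CO)CCn1cnc2cnc(N)nc21` is not yet measured. It differs from compound 1 by methyl in place of isopropyl on a saturated chain carbon bound to an oxygen next to a carbonyl group. This is the same kind of change as the measured step, but smaller: the isopropyl is not lost fully but reduced to methyl. Going by the values given here, the only step that bears on it is the one from compound 1 to compound 2, and a part of that rise is expected here, in the same direction, beyond the scatter. The expected step is a 4.0-fold higher number from compound 1 to compound 3 (0.60 log units; beyond the scatter). Compound 3 is therefore estimated at 6000 ug/mL, in the range 3000 ug/mL to 12000 ug/mL.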

Compound 3, solubility: 20000 ug/mL
The estimate for compound 3 lay 3.3-fold (0.52 log units) below the measured number; the whole stated range lies below it.
By their numbers in this assay, from the lowest: compound 1; then compounds 2 and 3 (each within the scatter of the next).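

In this assay, methyl in place of isopropyl on a saturated chain carbon bound to an oxygen next to a carbonyl group is a large step, with a 13-fold higher number from compound 1 to compound 3 (1.12 log units; beyond the scatter). Methyl in place of hydrogen at the same place gives a 1.4-fold higher number from compound 2 to compound 3 (0.15 log units; within the scatter), which lies within the scatter, so this pair cannot be ordered and the rise seen with compound 2 is matched by the ethoxycarbonyl of compound 3, so at this position the series separates only compound 1 from the other two. No supporting measurement accounts for this pattern.

Open, going by these compounds, is how the number behaves between ethyl and isobutyl, and whether a straight propyl or butyl chain would read with compound 1 or with compounds 2 and 3. On these data alone, a longer chain, or an amine or carboxylic acid on the carbonate chain, also remains open.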